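Swapping a Cyanophenyl Amide for an Oxazolyl Amide

A few compounds are considered here, and "the series" means these few. Any claim that something is new, unique, unknown or untested is made for them only; others in the source may bear on it.

Compound 1 `C/C=C/C(=O)Nc1c(C(O)(C(F)(F)F)C(F)(F)F)ccc2ccccc12` gives 49 nM in a functional assay (Sus scrofa) with sulfonylurea receptors; K-ATP channels (Homo sapiens) as the target; a lower number here means that less compound is needed, a higher number that more compound is needed for the effect. Compound 2 `N#Cc1cccc(C(=O)Nc2c(C(O)(C(F)(F)F)C(F)(F)F)ccc3ccccc23)c1` gives 372 nM in this assay, the higher of the two numbers, reached through a 7.6-fold higher number from compound 1 to compound 2 (0.88 log units; beyond the scatter). Compound 3 `O=C(Nc1c(C(O)(C(F)(F)F)C(F)(F)F)ccc2ccccc12)c1cnco1` carries 1,3-oxazol-5-yl in place of 3-cyanophenyl on a carbonyl carbon. Among the measured compounds shown here, the only measured step concerns a different exchange on a carbonyl carbon, so nothing bears directly on this change, and the expected step is one within the scatter, leaning slightly toward a lower number, a 1.7-fold lower number from compound 2 to compound 3 (0.23 log units; within the scatter). Compound 3 is therefore estimated at 220 nM, with a range from 60 nM to 800 nM.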

Compound 3, half-maximal effective concentration: 302 nM
Beside the measured number, compound 3's estimate is 1.4-fold (0.14 log units) below it, within the range that was stated.
By their numbers in this assay, from the lowest: compound 1; then compounds 3 and 2 (each within the scatter of the next).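

In this assay, putting 1,3-oxazol-5-yl in place of 3-cyanophenyl on the carbonyl carbon gives a 1.2-fold lower number from compound 2 to compound 3 (0.09 log units; within the scatter) and so leaves the result effectively unchanged. A five-membered aromatic ring with 2 hetero atoms therefore serves here as well as a six-membered aromatic ring of carbon only. Neither ring matches prop-1-en-1-yl, since replacing that group with 1,3-oxazol-5-yl gives a 6.2-fold higher number from compound 1 to compound 3 (0.79 log units; beyond the scatter) in a step that lies beyond the scatter.

From the compounds shown here alone, whether an amine, a carboxylic acid or a longer chain at this place would reach the number of compound 1 stays open. Nothing available explains why these steps take the sizes they do.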